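The source may report more compounds than this note shows. Statements on the series, on what has been measured and on what is new or still open speak of the compounds shown alone.

Measured compounds and their values in a functional assay on KB cells (Homo sapiens) for inhibition, with a stated time of 72 h; on this read-out higher numbers stand for weaker inhibition and lower numbers for stronger inhibition:
compound 1, `COc1ccc(S(=O)(=O)N2CCc3cccc(-c4ccc(F)nc4)c32)cc1`, 143 nM;
compound 2, `COc1ccc(S(=O)(=O)N2CCc3cccc(-c4ccc(N(C)C)cc4)c32)cc1`, 539 nM;
compound 3, `COc1ccc(S(=O)(=O)N2CCc3cccc(-c4cccc(F)c4)c32)cc1`, 98.5 nM.

Among these three numbers compound 1 stands second highest: compound 3 is its nearest neighbour, with a 1.5-fold lower number from compound 1 to compound 3 (0.16 log units; within the scatter), and compound 2 is the furthest, with a 3.8-fold higher number from compound 1 to compound 2 (0.58 log units; beyond the scatter). Compound 4, `COc1ccc(S(=O)(=O)N2CCc3cccc(-c4cccs4)c32)cc1`, is not yet measured. It differs from compound 1 in one place: thiophen-2-yl in place of 6-fluoropyridin-3-yl on an aromatic carbon.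

Two measured steps start from the same position of the shared core. The step to the 4-(dimethylamino)phenyl analogue, a 3.8-fold higher number from compound 1 to compound 2 (0.58 log units; beyond the scatter), is modest and beyond the scatter; the step to the 3-fluorophenyl analogue, a 1.5-fold lower number from compound 1 to compound 3 (0.16 log units; within the scatter), stays within it. Thiophen-2-yl is a small aromatic ring of five heavy atoms with one acceptor, closer in kind to the small aromatic groups of compound 1 and compound 3 than to the larger substituted ring of compound 2. Because the comparable step a 1.5-fold lower number from compound 1 to compound 3 (0.16 log units; within the scatter) stayed within the scatter, no step beyond the scatter is expected here; compound 4 is estimated at 130 nM, between 50 nM and 350 nM, which is expected to mean a 1.1-fold lower number from compound 1 to compound 4 (0.04 log units; within the scatter).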

Compound 4, half-maximal inhibitory concentration: 215 nM
Compound 4: middle estimate off by 1.7-fold (0.22 log units), on the low side; low and high end bracket the measured number.
By their numbers in this assay, from the lowest: compounds 3, 1 and 4 (each within the scatter of the next, the first and the last beyond it); then compound 2.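

In this assay, going by these compounds alone, the earlier compounds carried only six-membered aromatic rings at this position, and compound 4 shows that a five-membered one can stand there without a step beyond the scatter: thiophen-2-yl in place of 6-fluoropyridin-3-yl gives a small change (a 1.5-fold higher number from compound 1 to compound 4 (0.18 log units; within the scatter)). The same ring does separate from both phenyl analogues, on one side (a 2.2-fold higher number from compound 3 to compound 4 (0.34 log units; beyond the scatter)) and on the other (a 2.5-fold lower number from compound 2 to compound 4 (0.40 log units; beyond the scatter)), so the two fluorinated rings do not behave as one group against it. Nothing measured here accounts for these differences.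

The compounds shown leave open how this position responds to a saturated amine such as piperidine or to a carboxylic acid, as every group here is an aromatic ring. On these data alone, whether thiophen-3-yl would match thiophen-2-yl also remains open.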